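This account rests on a few compounds, and the source may have more. Where it says the series, first, only, none or still open, it means among the compounds named here.

Of the compounds shown here, three have so far been tested in an ADME assay on Huh-7 cells (Homo sapiens) for cytotoxicity; on this read-out higher numbers stand for lower toxicity in this test and lower numbers for higher toxicity in this test. Compound 1, `CN1CCN(CCCNCc2cn(-c3ccc([N+](=O)[O-])cc3)nc2-c2ccc(Cl)cc2)CC1`, gives 3700 nM. Compound 2, `Cc1ccccc1-c1nn(-c2ccc(F)cc2F)cc1CNCCN(C)C`, stops at the limit of the test, reported as > 20000 nM, so no number is available for it. Compound 3, `Cc1c(CNCCN2CCN(C)CC2)c(-c2ccccc2)nn1-c1ccc(F)cc1`, likewise stops at the limit, reported as > 20000 nM. Compound 2 therefore sits at the limit, as does compound 3, while compound 1 yields a number. Compound 4, `Cc1ccccc1-c1nn(-c2ccc(F)cc2F)cc1CNCCN1CCN(C)CC1`, has not yet been measured and differs from compound 2 in one place: 4-methylpiperazin-1-yl in place of dimethylamino on a saturated chain carbon, two bonds along the chain from an amine nitrogen. Within the data shown here, no measured step of this kind exists here, so the change is expected to move this assay by no more than the usual scatter, because of the limit of > 20000 nM in this assay, at which 2 of the 3 values shown sit. Compound 4 is expected at about 20000 nM, between 8000 nM and 40000 nM, a step of a number no higher from compound 2 to compound 4 (the limit leaves the size open).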

Compound 4, half-maximal cytotoxic concentration: > 20000 nM
Compound 4 was reported as a limit (the forecaster's own chance of this, stated with the estimate: 70%); the middle value sits exactly at the limit.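

Among these compounds, compound 2 and compound 4 are both reported only as limits, so no step between them can be read. The compounds shown leave open whether 4-methylpiperazin-1-yl in place of dimethylamino changes the result at all.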